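Working notes: cytotoxicity in the series, compound 2 to compound 3

The source may report more compounds than this note shows. Statements on the series, on what has been measured and on what is new or still open speak of the compounds shown alone.

Measured so far:
compound 1 `CCCCNc1nc(N)nc2ccn(Cc3ccc4ccccc4n3)c12` — > 24000 nM
compound 2 `COCCCNc1nc(N)nc2ccn(Cc3ccccn3)c12` — > 24000 nM

In an ADME assay on HEK293 cells (Homo sapiens) for cytotoxicity, read by ATP content, with a stated time of 6 h (on this read-out higher numbers stand for lower toxicity in this test and lower numbers for higher toxicity in this test), compound 1 gives only a limit, > 24000 nM. Compound 2 likewise gives only a limit, > 24000 nM. Both readings sit at the same point, (the limit of > 24000 nM in this assay, at which 2 of the 2 values shown sit). Going by the values given here, compound 2 therefore stands at the limit of this assay with no number of its own, and the two measured compounds show nothing more than that neither reaches a measurable toxicity here; no step between them is computed.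

Compound 3 `Cc1cnc(CNc2nc(N)nc3ccn(Cc4ccccn4)c23)s1` differs from compound 2 in one place: 5-methyl-1,3-thiazol-2-yl in place of 2-methoxyethyl on a saturated chain carbon bound to a nitrogen on an aromatic ring. The change sits on a saturated chain carbon bound to a nitrogen on an aromatic ring, so that the 3-methoxypropyl chain becomes a (5-methyl-1,3-thiazol-2-yl)methyl group.

With both measured compounds at the limit, the step of a number no higher from compound 2 to compound 3 (the limit leaves the size open) is expected to be none beyond the scatter in this assay. Compound 3 is accordingly estimated at 24000 nM, with a range of 10000 nM to 50000 nM, and is expected most probably to be reported as a limit again.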

Compound 3, half-maximal cytotoxic concentration: > 24000 nM
Compound 3 was reported as a limit; the forecaster's own chance of this, stated with the estimate: 75%; the middle value lies on the limit itself.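

No step can be read from compound 2 to compound 3 in this assay because both compounds give only a limit: the limit of > 24000 nM in this assay, at which 3 of the 3 values shown sit.

The compounds shown leave open whether replacing 3-methoxypropyl with (5-methyl-1,3-thiazol-2-yl)methyl changes the half-maximal cytotoxic concentration at all, and how large any such change would be.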